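The source may hold more compounds than are shown below. What is called first, only, known or untested is meant among the compounds shown, and "the series" means these compounds.

Measured compounds:
- compound 1, `CS(=O)(=O)N1CCCC(NC(=O)[C@H](CCC2CCCCC2)NC(=O)c2ccc(CNC(=O)c3cc(-c4ccccc4)n[nH]3)cc2)C1`: 21500 nM
- compound 2, `CC(NC(=O)c1cc(-c2ccccc2)n[nH]1)c1ccc(C(=O)N[C@@H](CCC2CCCCC2)C(=O)NC2CCCN(S(C)(=O)=O)C2)cc1`: 27700 nM
- compound 3, `Cn1ncc(C(=O)NCc2ccc(C(=O)N[C@@H](CCC3CCCCC3)C(=O)NC3CCCN(S(C)(=O)=O)C3)cc2)c1N`: 1160 nM

All three numbers come from an assay on HEK293T cells for inhibition of Discoidin domain-containing receptor 2 (Homo sapiens), read by NanoBRET, with a stated time of 2 h; a higher number here means a weaker inhibitor, a lower number a stronger inhibitor. Compounds 1 and 2 share one core; compound 3 has a different core, the difference being (a group of 7 heavy atoms (4 carbon, 3 nitrogen; one five-membered aromatic ring with 2 hetero atoms) in place of a group of 11 heavy atoms (9 carbon, 2 nitrogen; one five-membered aromatic ring with 2 hetero atoms, one six-membered aromatic ring of carbon only), on a carbonyl carbon), and that change brought a 19-fold lower number from compound 1 to compound 3 (1.27 log units; beyond the scatter). Compound 3 therefore has the lowest number of the three.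

The change studied here is methyl in place of hydrogen on a saturated chain carbon bound to an amide-type nitrogen and an aromatic carbon. Between compounds 1 and 2 it produced a 1.3-fold higher number from compound 1 to compound 2 (0.11 log units; within the scatter), so the two numbers cannot be told apart. Compound 4, `CC(NC(=O)c1cnn(C)c1N)c1ccc(C(=O)N[C@@H](CCC2CCCCC2)C(=O)NC2CCCN(S(C)(=O)=O)C2)cc1`, carries the same change on the core of compound 3: methyl in place of hydrogen on a saturated chain carbon bound to an amide-type nitrogen and an aromatic carbon. The place is the same in every word, so this is the same change, only on the other core.

Nothing in these data suggests the methyl behaves differently on the core of compound 3, so the step from compound 3 to compound 4 is expected to be small, near a 1.3-fold higher number from compound 3 to compound 4 (0.11 log units; within the scatter), because the earlier step was a 1.3-fold higher number from compound 1 to compound 2 (0.11 log units; within the scatter). Compound 4 is therefore estimated at 1500 nM in this assay, with a likely range from 700 nM to 3500 nM.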

Compound 4, half-maximal inhibitory concentration: 7460 nM
For compound 4 the middle estimate is 5.0-fold (0.70 log units) below the measured one; the whole stated range lies below it.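

In this assay, among the compounds shown here, methyl in place of hydrogen on the saturated chain carbon brings a 6.4-fold higher number from compound 3 to compound 4 (0.81 log units; beyond the scatter), and this step differs from the one the same change gave on the core of compound 1: the same change on two cores in this assay, a 1.3-fold higher number (0.11 log units; within the scatter) from compound 1 to compound 2 and a 6.4-fold higher number (0.81 log units; beyond the scatter) from compound 3 to compound 4, 5.0-fold (0.70 log units) apart, beyond the scatter of two such steps. Read the other way, exchanging the group on the carbonyl carbon when the methyl is present brings a 3.7-fold lower number from compound 2 to compound 4 (0.57 log units; beyond the scatter), and this differs from the same exchange without the methyl: the same change on two cores in this assay, a 19-fold lower number (1.27 log units; beyond the scatter) from compound 1 to compound 3 and a 3.7-fold lower number (0.57 log units; beyond the scatter) from compound 2 to compound 4, 5.0-fold (0.70 log units) apart, beyond the scatter of two such steps. The two changes therefore do not add up independently here, so a step measured on one core did not carry over to the other, but this rests on a single set of four compounds and does not show why the cores differ or how a third core would respond.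

As far as these compounds go, it remains open whether an ethyl group on the same carbon would raise the number further on the core of compound 3. From the compounds shown here alone, it also remains open whether a hydroxymethyl group there would behave as methyl does on either core.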